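The compounds below may be only part of what the source reports. "The series", "measured", "known", "first", "only" and "open" are said of these compounds alone.

Measured so far in a functional assay on HeLa cells (Homo sapiens) for cytotoxicity, read by WST assay, with a stated time of 48 h; a higher number here means a weaker inhibitor, a lower number a stronger inhibitor:

Compound 1 `O[C@@H](c1ccccc1)[C@H]1CO[C@H](c2ccccc2)[C@@H](C/C=C/c2ccncc2)C1`: > 100000 nM
Compound 2 `COc1ccc(/C=C/C[C@@H]2C[C@H]([C@H](O)c3ccc(OC)c(OC)c3)CO[C@H]2c2ccc(OC)c(OC)c2)cc1OC`: 28700 nM
Compound 3 `COc1ccc(/C=C/C[C@@H]2C[C@@H]([C@@H](OC)c3ccc(OC)c(OC)c3)CO[C@H]2c2ccc(OC)c(OC)c2)cc1OC`: > 100000 nM

In this assay the value for compound 1 is a limit of the assay, not a number. The value for compound 3 is likewise a limit. Only compound 2 gives a measured number. Compound 1 therefore stands at the limit of > 100000 nM in this assay, at which 2 of the 3 values shown sit, and cannot be ranked more closely.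

Compound 4 `O=[N+]([O-])c1ccccc1/C=C/C[C@H]1C[C@@H]([C@@H](O)c2ccccc2)CO[C@@H]1c1ccccc1` differs from compound 1 in one place: 2-nitrophenyl in place of pyridin-4-yl on a double-bonded chain carbon bound to a double-bonded chain carbon. No measured step between any two of these compounds is available, so the size of this change cannot be read from the data. The expected step is a number no higher from compound 1 to compound 4 (the limit leaves the size open), not beyond the scatter. Compound 4 is expected to give about 100000 nM, within a range from 30000 nM to 300000 nM, most likely reported again only as a limit.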

Compound 4, half-maximal inhibitory concentration: 11800 nM
Estimate against measurement, compound 4: 8.5-fold (0.93 log units) above; the measured number lies below the stated range.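

In this assay, the group on a double-bonded chain carbon bound to a double-bonded chain carbon clearly matters: 2-nitrophenyl in place of pyridin-4-yl gives an at least 8.4-fold lower number from compound 1 to compound 4 (0.92 log units; beyond the scatter). The full size of this step cannot be read, because the value of compound 1 is a limit: the limit of > 100000 nM in this assay, at which 2 of the 4 values shown sit.

The change swaps the ring and adds the nitro group in one move, so the compounds shown do not tell which of the two matters. Also open, on these data alone, is whether plain phenyl, or 2-aminophenyl, at this place would give a similar number.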